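Dichlorothiophene swap on the pyrazoline core of the series

The compounds below may be only part of what the source reports. "The series", "measured", "known", "first", "only" and "open" are said of these compounds alone.

Measured compounds in an ADME assay on PBMC cells (Homo sapiens) for cytotoxicity, with a stated time of 5 days; a lower number here means a stronger inhibitor, a higher number a weaker inhibitor:
compound 1 `Cc1ccsc1C(=O)/C=C/c1ccc(N2CCCCC2)cc1` gives 26400 nM;
compound 2 `O=C(/C=C/c1ccc(N2CCCCC2)cc1)c1cc(Cl)sc1Cl` gives 42800 nM;
compound 3 `Cc1csc(C2=NNC(c3ccc(N4CCCCC4)cc3)C2)c1` gives 24400 nM.

Compound 3 sits at the low end of the three numbers in this assay, yet its distance to compound 1 and to compound 2 is within the scatter, so the three read as one level.

Compound 4 `Clc1cc(C2=NNC(c3ccc(N4CCCCC4)cc3)C2)c(Cl)s1` is not yet measured. It differs from compound 3 in one place: 2,5-dichlorothiophen-3-yl in place of 4-methylthiophen-2-yl on a carbon with a double bond to nitrogen. The same pair of groups was exchanged on a carbonyl carbon between compound 1 and compound 2, where a 1.6-fold higher number from compound 1 to compound 2 (0.21 log units; within the scatter). Among the compounds with values here, that single step is the only direct guide for the new pair; compound 1 and compound 3 carry slightly different methylthiophenyl groups, so the parallel is close but not exact.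

With one step of that size behind it, and that step inside the scatter, no shift beyond the scatter is expected for compound 4 in this assay, and the expected step of a 1.4-fold higher number from compound 3 to compound 4 (0.16 log units; within the scatter) leans slightly toward a higher number. The estimate for compound 4 is 35000 nM, with a range from 15000 nM to 80000 nM.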

Compound 4, half-maximal inhibitory concentration: 59000 nM
Compound 4: the middle estimate sits 1.7-fold (0.23 log units) below what was measured, within the range that was stated.
By their numbers in this assay, from the lowest: compounds 3, 1, 2 and 4 (each within the scatter of the next, the first and the last beyond it).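

In this assay, within the data shown here, the exchange of 4-methylthiophen-2-yl for 2,5-dichlorothiophen-3-yl on the carbon with a double bond to nitrogen gives a 2.4-fold higher number from compound 3 to compound 4 (0.38 log units; beyond the scatter), the first single change in this set to reach beyond the scatter, so this place on the shared core does respond to the thiophene group, though modestly. The related exchange on a carbonyl carbon gave a 1.6-fold higher number from compound 1 to compound 2 (0.21 log units; within the scatter), which points the same way, but the leaving methylthiophenyl groups are not identical and one pair on each core cannot establish that the two places truly differ in their response. No supporting measurement bears on the origin of the rise.

The compounds shown leave open which feature of the entering group carries the shift, as its two chlorine atoms and its changed point of attachment arrive together in a single exchange. A chlorothiophene, or a thiophene bearing a carboxylic acid, on this same carbon would show whether the higher number follows the chlorine atoms or holds for other thiophene substituents.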